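A few compounds are considered here, and "the series" means these few. Any claim that something is new, unique, unknown or untested is made for them only; others in the source may bear on it.

Within the data shown here, compound 1 `CCCOc1ccc(C(=O)/C=C/c2ccccc2)c(O)c1` is the only member of the series with a reading so far. In a functional assay on Ca-Ski cells (Homo sapiens) for antiproliferative activity, with a stated time of 48 h (a higher number here means a weaker inhibitor, a lower number a stronger inhibitor), compound 1 gives only a limit, > 50000 nM, not a number. Compound 2 `CCOc1ccc(C(=O)/C=C/c2ccccc2)c(O)c1` has no result in this assay, shown as "not determined" (no result reported), so compound 2 stands nowhere on the numbers; the set holds just (the limit of > 50000 nM in this assay, at which 1 of the 2 values shown sits). Compound 3 `CC(=O)Oc1ccc(C(=O)/C=C/c2ccccc2)c(O)c1` differs from compound 2 by acetyl in place of ethyl on an oxygen on an aromatic ring. Among the measured compounds shown here, with no measured step to size this change, and the series anchored by a single limit, no shift beyond the scatter in this assay can be foreseen in either direction. Compound 3 is expected near 40000 nM, estimated between 10000 nM and 100000 nM, with a real chance that this assay again returns only a limit.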

Compound 3, half-maximal inhibitory concentration: > 50000 nM
Compound 3: only a limit was reported (the forecaster's own chance of this, stated with the estimate: 50%); middle value at least 1.2-fold (0.09 log units) from the limit.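

No step can be read between compound 1 and compound 3, as each gives only a limit: the limit of > 50000 nM in this assay, at which 2 of the 3 values shown sit.

Still open, going by these compounds, is whether any group on that oxygen would give a numerical reading in this assay.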